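Ethynyl in place of furan-3-yl: working notes

The source may report more compounds than this note shows. Statements on the series, on what has been measured and on what is new or still open speak of the compounds shown alone.

In a functional assay on A549 cells (Homo sapiens), read by MTT assay, with a stated time of 72 h (a lower number here means a stronger inhibitor, a higher number a weaker inhibitor), compound 1 `COc1ncnc2c1c(-c1ccccc1)cn2[C@@H]1O[C@H](CO)[C@@H](O)[C@H]1O` gives > 20000 nM as a limit. Compound 2 `Nc1nc(N)c2c(-c3cc4ccccc4o3)cn([C@@H]3O[C@H](CO)[C@@H](O)[C@H]3O)c2n1` gives > 20000 nM as a limit. Compound 3 `Cc1nc(N)c2c(-c3ccoc3)cn([C@@H]3O[C@H](CO)[C@@H](O)[C@H]3O)c2n1` gives > 20000 nM as a limit. Compound 3 therefore sits at the limit of > 20000 nM in this assay, at which 3 of the 3 values shown sit, and cannot be ranked against the others.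

Compound 4 `C#Cc1cn([C@@H]2O[C@H](CO)[C@@H](O)[C@H]2O)c2nc(C)nc(N)c12` differs from compound 3 by ethynyl in place of furan-3-yl on an aromatic carbon in one place, with ethynyl in place of furan-3-yl on an aromatic carbon. Within the data shown here, no measured pair gauges this change. The step expected in this assay is modest and runs towards stronger inhibition, and a reading at the limit remains quite possible. The estimated step is an at least 2.2-fold lower number from compound 3 to compound 4 (0.34 log units; beyond the scatter) on this reading. For compound 4 the estimate is 9000 nM with an expected range from 1000 nM to 20000 nM in this assay.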

Compound 4, half-maximal inhibitory concentration: > 20000 nM
Compound 4 gave a limit, no number (the forecaster's own chance of this, stated with the estimate: 50%); middle value at least 2.2-fold (0.34 log units) from the limit.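

Among these compounds, no step from compound 3 to compound 4 can be read, since both values are limits: the limit of > 20000 nM in this assay, at which 4 of the 4 values shown sit.

The compounds shown leave open whether ethynyl in place of furan-3-yl changes inhibition at all, as none gives a measurable number.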